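Hydrogen in Place of Cyano on Compound 1

The compounds below may be only part of what the source reports. "The series", "measured", "known", "first", "only" and "open" are said of these compounds alone.

Compound 1 `N#Cc1cccc(-n2nnc3c(C(N)=O)ncn3c2=O)c1` with 0.0433 h measured
Compound 2 `CCOc1ccc(-n2nnc3c(C(N)=O)ncn3c2=O)cc1` with 1.3 h measured

In an ADME assay for pharmacokinetics (on this read-out lower numbers stand for a shorter-lived compound and higher numbers for a longer-lived compound), compound 1 holds the lower of the two numbers, and its gap to compound 2 lies beyond the scatter. Compound 3 `NC(=O)c1ncn2c(=O)n(-c3ccccc3)nnc12` has not yet been measured. It carries hydrogen in place of cyano on an aromatic carbon and otherwise matches compound 1. Going by the values given here, no measured step shows what this change does, so the expectation rests on the two values alone. Compound 1 at 0.0433 h marks the bottom of the measured span and compound 2 at 1.3 h marks its top, and compound 3 is expected to fall inside that span. An upward move in this assay beyond the scatter is expected, estimated as a 6.9-fold higher number from compound 1 to compound 3 (0.84 log units; beyond the scatter) on this reading. Compound 3 is expected at 0.3 h with an estimated range of 0.1 h to 1 h for the coming measurement.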

Compound 3, half-life: 0.383 h
Compound 3: the middle estimate sits 1.3-fold (0.11 log units) below what was measured; low and high end bracket the measured number.
By their numbers in this assay, from the lowest: compound 1; then compound 3; then compound 2.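

In this assay, the loss of cyano alone brings a clear rise (an 8.8-fold higher number from compound 1 to compound 3 (0.95 log units; beyond the scatter)), which shows that the half-life of this series responds to what sits on this aromatic carbon and that the nitrile-bearing compound 1 lies well below its unsubstituted counterpart. The loss of ethoxy moves the number the other way (a 3.4-fold lower number from compound 2 to compound 3 (0.53 log units; beyond the scatter)), so compound 3 sits between the two, with one substituent below it and the other above it, both beyond the scatter. Nothing at hand explains either shift.

From the compounds shown here alone, each group is represented by a single compound, so it remains open whether an amine, a methoxy group or a longer alkoxy chain on this ring would follow ethoxy upward or cyano downward. Going by these compounds, the effect of moving cyano or ethoxy to another carbon of the ring also remains open.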